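A few compounds are considered here, and "the series" means these few. Any claim that something is new, unique, unknown or untested is made for them only; others in the source may bear on it.

Compound 1 `CC(C)n1ncc2c(C(=O)NCc3cn(-c4ccccc4)nn3)cccc21`: in a functional assay on MCF7 cells (Homo sapiens) for inhibition, read by MTT assay, with a stated time of 72 h (on this read-out higher numbers stand for weaker inhibition and lower numbers for stronger inhibition), compound 1 gives > 40000 nM, which is a limit of the assay and not a number.
Compound 2 `Cc1ccc(-n2cc(CNC(=O)c3cccc4c3cnn4C(C)C)nn2)c(C)c1`: in this assay compound 2 gives > 40000 nM, again a limit of the assay rather than a number.

For the measured compounds named here, compound 2 therefore stands at the limit of this assay, and the only other measured value sits at the same limit, so where compound 2 stands relative to compound 1 cannot be read. Going by the values given here, the single measured step, a step that the two limits leave unreadable from compound 1 to compound 2, is hidden by the two limits. Compound 3 `CC(C)n1ncc2c(C(=O)NCc3cn(-c4ccc(I)cc4)nn3)cccc21` differs from compound 2 by 4-iodophenyl in place of 2,4-dimethylphenyl on an aromatic nitrogen. Among the compounds with values here, no measured step touches an iodine substituent, and the step from compound 1 to compound 2 offers no readable size, since (the limit of > 40000 nM in this assay, at which 2 of the 2 values shown sit). With both measured values at the limit, compound 3 is expected most likely to be reported as a limit too, and the step that the limit leaves unreadable from compound 2 to compound 3 is expected to show no readable change. The estimate for compound 3 is 60000 nM, with a range from 20000 nM to 200000 nM.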

Compound 3, half-maximal inhibitory concentration: > 40000 nM
Compound 3: only a limit was reported; the forecaster's own chance of this, stated with the estimate: 85%; the middle value lies beyond the limit too.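

For the compounds shown here, no step from compound 1 or compound 2 to compound 3 can be read, since all three compounds give a limit and not a number: the limit of > 40000 nM in this assay, at which 3 of the 3 values shown sit.

The compounds shown leave open how strongly each one inhibits, and whether phenyl, 2,4-dimethylphenyl and 4-iodophenyl differ at all in this assay.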